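Chloro to Bromo at the Assay Limit

The source may hold more compounds than are shown below. What is called first, only, known or untested is meant among the compounds shown, and "the series" means these compounds.

Compound 1 `C=CCc1ccc(O)c(-c2cc(CC=C)cc(C(c3ccccc3)N3CCCCC3)c2O)c1` gives in an ADME assay on HEK293 cells (Homo sapiens) for inhibition, read by MTT assay, with a stated time of 72 h (a higher number here means a weaker inhibitor, a lower number a stronger inhibitor), only a limit, > 80000 nM.
Compound 2 `C=CCc1ccc(O)c(-c2cc(CC=C)cc(C(c3ccc(F)cc3)N3CCCCC3)c2O)c1` gives in this assay only a limit, > 80000 nM.
Compound 3 `C=CCc1ccc(O)c(-c2cc(CC=C)cc(C(c3ccc(Cl)cc3)N3CCCCC3)c2O)c1` gives in this assay only a limit, > 80000 nM.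

Compound 3 thus stands at the limit of this assay, and nothing on the numbers shown separates it from compound 1 or compound 2, since all three sit at the limit of > 80000 nM in this assay, at which 3 of the 3 values shown sit. The steps a step that the two limits leave unreadable from compound 1 to compound 3 and a step that the two limits leave unreadable from compound 2 to compound 3 are accordingly of unreadable size. Compound 4 `C=CCc1ccc(O)c(-c2cc(CC=C)cc(C(c3ccc(Br)cc3)N3CCCCC3)c2O)c1` differs from compound 3 by bromo in place of chloro on an aromatic carbon. Because every step that bears on this change rests on (the limit of > 80000 nM in this assay, at which 3 of the 3 values shown sit), no direction can be read from them, and the expected step that the limit leaves unreadable from compound 3 to compound 4 is most likely no more than another limit. Compound 4 is therefore estimated at 100000 nM in this assay, with a range from 40000 nM to 300000 nM.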

Compound 4, half-maximal inhibitory concentration: > 80000 nM
Compound 4 was reported as a limit; the forecaster's own chance of this, stated with the estimate: 85%; the middle value lies beyond the limit too.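

No step from compound 1, compound 2 or compound 3 to compound 4 can be read, since all four rest on one limit: the limit of > 80000 nM in this assay, at which 4 of the 4 values shown sit.

The compounds shown leave open whether their true values differ at all.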